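This account rests on a few compounds, and the source may have more. Where it says the series, first, only, none or still open, it means among the compounds named here.

Compound 1 `COC(=O)c1ccc(C2SCC(=O)N2c2ccc(N3CCN(S(=O)(=O)c4ccc([N+](=O)[O-])cc4)CC3)cn2)c(OC)c1` gives 65200 nM in a functional assay on K562 cells (Homo sapiens) for antiproliferative activity, read by MTT assay and trypan blue exclusion, with a stated time of 72 h; a lower number here means a stronger inhibitor, a higher number a weaker inhibitor. Compound 2 `COC(=O)c1ccc(C2SCC(=O)N2c2ccc(N3CCN(S(=O)(=O)c4cc(Cl)ccc4Cl)CC3)cn2)c(OC)c1` reaches only a limit of this assay, > 100000 nM. Compound 3 `COC(=O)c1ccc(C2SCC(=O)N2c2ccc(N3CCN(Cc4cc(OC)c(OC)c(OC)c4)CC3)cn2)c(OC)c1` likewise reaches only a limit, > 100000 nM. Going by the values given here, the one measured step, an at least 1.5-fold higher number from compound 1 to compound 2 (0.18 log units; that floor lies within the scatter), swaps one aryl group on the sulfonyl sulfur for another. Compound 2 thus sits at the limit of > 100000 nM in this assay, at which 2 of the 3 values shown sit. Compound 4 `COC(=O)c1ccc(C2SCC(=O)N2c2ccc(N3CCN(S(=O)(=O)c4ccc(OC)cc4)CC3)cn2)c(OC)c1` differs from compound 2 by 4-methoxyphenyl in place of 2,5-dichlorophenyl on a sulfonyl sulfur. Among the compounds with values here, the step from compound 1 to compound 2 is the only comparable change and ends in a limit, so no clear direction in this assay can be drawn from it. The estimate for compound 4 is 100000 nM, between 30000 nM and 300000 nM, meaning an expected a number no higher from compound 2 to compound 4 (the limit leaves the size open).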

Compound 4, half-maximal inhibitory concentration: 54500 nM
Compound 4: middle estimate off by 1.8-fold (0.26 log units), on the high side; the measured number falls inside the stated range.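

In this assay, a second para-substituted aryl group on the sulfonyl sulfur now has a measured number. With a 1.2-fold lower number from compound 1 to compound 4 (0.08 log units; within the scatter) methoxy and nitro on that aromatic carbon are not told apart. With an at least 1.8-fold lower number from compound 2 to compound 4 (0.26 log units; that floor lies within the scatter) the comparison with 2,5-dichlorophenyl yields only a floor, and compound 2 remains a limit: the limit of > 100000 nM in this assay, at which 2 of the 4 values shown sit.

As far as these compounds go, whether 4-methoxyphenyl truly differs from 2,5-dichlorophenyl stays open. Also open, from the compounds shown here alone, is what an amine or a carboxylic acid on that aromatic carbon would give in this assay.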